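Nitro to cyano on the arylpiperazine of compound 1

The source may report more compounds than this note shows. Statements on the series, on what has been measured and on what is new or still open speak of the compounds shown alone.

Compound 1 `O=C(CCN1CCN(c2ccc([N+](=O)[O-])cc2)CC1)c1csc2ccccc12` is the nitro-substituted arylpiperazine of the series. In an assay on HEK293 cells for displacement of a labelled ligand from 5-hydroxytryptamine receptor 7 (Homo sapiens), read by scintillation counting, with a stated time of 1 h (a higher number here means a weaker inhibitor, a lower number a stronger inhibitor), compound 1 gives > 100000 nM, which is a limit of the assay and not a number (the limit of > 100000 nM in this assay, at which 1 of the 3 values shown sits). Compound 3 `O=C(CCN1CCN(c2ccc([N+](=O)[O-])cc2)CC1)c1csc2ccc(F)cc12` carries a fluorine on the shared core and in this assay compound 3 gives 91200 nM; the step of an at least 1.0-fold lower number from compound 1 to compound 3 (0.04 log units; that floor lies within the scatter) therefore stays within the scatter. Going by the values given here, compound 2 `N#Cc1ccc(N2CCC(NCCC(=O)c3csc4ccccc34)CC2)cc1` has a cyanophenyl group on a different linker, and in this assay compound 2 gives 7240 nM; no single-point step connects compound 2 to compound 1, so the two values are only set side by side.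

Compound 4 `N#Cc1ccc(N2CCN(CCC(=O)c3csc4ccccc34)CC2)cc1` is not yet measured. It differs from compound 1 by cyano in place of nitro on an aromatic carbon. Among the compounds with values here, no measured step covers this exchange on the same linker. Within the data shown here, the one measured step from compound 1, to compound 3, lay within the scatter and touches a different position. The value of compound 2 shows that a cyanophenyl group can sit within the measurable range of this assay. Compound 4 is therefore expected to move downward from the limit, with the step of an at least 3.3-fold lower number from compound 1 to compound 4 (0.52 log units; beyond the scatter) as the estimate. For compound 4 the expected value is 30000 nM, within a range from 5000 nM to 100000 nM.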

Compound 4, inhibition constant: > 100000 nM
Compound 4: only a limit was reported; the forecaster's own chance of this, stated with the estimate: 35%; middle value at least 3.3-fold (0.52 log units) from the limit.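

In this assay compound 4 gives > 100000 nM, which is a limit of the assay and not a number. Compound 1 stands at the same limit, so no step between compound 1 and compound 4 can be read: the limit of > 100000 nM in this assay, at which 2 of the 4 values shown sit.

On these data alone, whether cyano in place of nitro shifts the inhibition constant at all, and in which direction, stays open.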